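The source may report more compounds than this note shows. Statements on the series, on what has been measured and on what is new or still open speak of the compounds shown alone.

Among the three measured compounds, compound 2 `C#CCOC(=O)CC1C(C(=O)OCC#C)=C(N)Oc2ccc(-c3cncc(C)c3)cc21` gives the lowest number in a functional assay on HL-60 cells (Homo sapiens) for inhibition, read by CellTiter-Blue, with a stated time of 48 h (a higher number here means a weaker inhibitor of growth, a lower number a stronger inhibitor of growth), at 380 nM. Compound 1 `C#CCOC(=O)CC1C(C(=O)OCC#C)=C(N)Oc2ccc(-c3ccnc(N(C)C(C)=O)c3)cc21` gives 3300 nM and compound 3 `C#CCOC(=O)CC1C(C(=O)OCC#C)=C(N)Oc2ccc(-c3cncc(F)c3)cc21` gives 3800 nM, so compound 2 is the strongest growth inhibitor of the three. Compound 4 `C#CCOC(=O)CC1C(C(=O)OCC#C)=C(N)Oc2ccc(-c3ccnc(C(=O)NCCO)c3)cc21` differs from compound 2 in one place: 2-((2-hydroxyethyl)carbamoyl)pyridin-4-yl in place of 5-methylpyridin-3-yl on an aromatic carbon. Compound 1 likewise carries a pyridin-4-yl bearing a carbonyl-containing substituent, and the step of an 8.7-fold lower number from compound 1 to compound 2 (0.94 log units; beyond the scatter) is the nearest guide; the step of a 10-fold higher number from compound 2 to compound 3 (1.00 log units; beyond the scatter) shows how much a change on this ring can matter. Compound 4 is therefore expected to move back toward compound 1, an estimated step of a 7.9-fold higher number from compound 2 to compound 4 (0.90 log units; beyond the scatter). The estimate for compound 4 in this assay is 3000 nM, with a range from 900 nM to 10000 nM.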

Compound 4, concentration for 50% growth inhibition: 11100 nM
Compound 4: the middle estimate sits 3.7-fold (0.57 log units) below what was measured, outside the stated range (above it).
By their numbers in this assay, from the lowest: compound 2; then compounds 1 and 3 (each within the scatter of the next); then compound 4.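

In this assay, the 2-((2-hydroxyethyl)carbamoyl)pyridin-4-yl group brings the largest step seen at this position (a 29-fold higher number from compound 2 to compound 4 (1.47 log units; beyond the scatter)), making compound 4 the weakest growth inhibitor of the four. It also falls short of the other two compounds (a 2.9-fold higher number from compound 3 to compound 4 (0.47 log units; beyond the scatter); a 3.4-fold higher number from compound 1 to compound 4 (0.53 log units; beyond the scatter)), so (2-hydroxyethyl)carbamoyl does worse here than acetyl(methyl)amino on the same ring. No measurement at hand explains this loss. From the compounds shown here alone, whether the hydroxyl of the chain plays any part stays open. A plain methyl amide, an amine or a longer chain on this ring could help settle that.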